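Pyridyl regioisomer on the thiophene sulfonamide

This account rests on a few compounds, and the source may have more. Where it says the series, first, only, none or still open, it means among the compounds named here.

In an assay on isolated protein for inhibition of coagulation factor X (Oryctolagus cuniculus), tested at 1 uM (on this read-out higher numbers stand for more inhibition at the one concentration tested (going by the name of the read-out) and lower numbers for less inhibition), compound 2 `O=C1[C@@H](NS(=O)(=O)c2ccc(-c3ccncc3)s2)CCN1CCNc1ccncc1` gives 41%, the highest of the two numbers in hand; compound 1 `O=C1[C@@H](NS(=O)(=O)c2ccc(-c3ccccn3)s2)CCN1Cc1cc2[nH]cccc-2n1` gives 8%, which is beyond the scatter lower. Compound 3 `O=C1[C@@H](NS(=O)(=O)c2ccc(-c3ccccn3)s2)CCN1CCNc1ccncc1` is yet to be measured in this assay. It differs from compound 2 by pyridin-2-yl in place of pyridin-4-yl on an aromatic carbon. Since compound 1 also carries pyridin-2-yl and sits low, a modest downward step is expected for compound 3, though a step within the scatter would not surprise. The expected step from compound 2 to compound 3 is a number 16 percentage points lower from compound 2 to compound 3 (beyond the scatter). Compound 3 is estimated at 25%, between 5% and 50%.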

Compound 3, a percentage reported as inhibition, at one concentration (the size of the read-out at that concentration, not a potency): 18%
For compound 3 the middle estimate is 7 percentage points above the measured one, and the stated range covers the measured number.
By their numbers in this assay, from the lowest: compounds 1 and 3 (each within the scatter of the next); then compound 2.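

With the rest of the molecule held fixed, pyridin-2-yl in place of pyridin-4-yl next to the ring sulfur gives a number 23 percentage points lower from compound 2 to compound 3 (beyond the scatter) in this assay, so this position responds to the pyridyl attachment alone. With pyridin-2-yl held in place, exchanging the group on the saturated chain carbon gives a number 10 percentage points higher from compound 1 to compound 3 (within the scatter) and so shows no clear effect. Nothing measured here explains the pyridyl step. Open, on these data alone, is how phenyl or pyridin-3-yl would fare at this position. Also open, as far as these compounds go, is whether the side chain of compound 1 would behave alike alongside pyridin-4-yl.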